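Azido Replaces Amino on a Shared Core

This account rests on a few compounds, and the source may have more. Where it says the series, first, only, none or still open, it means among the compounds named here.

Compound 1, `Cc1nn(C)c2c1C(c1cccc(F)c1)=NCCN2`: 2.5 mg/kg
Compound 2, `Cc1nn(C)c2c1C(c1cccc(N)c1)=NCCN2`: 2.5 mg/kg

Compound 1 and compound 2 share one core and differ only in a single group on an aromatic carbon of a six-membered aromatic ring of carbon only. In a functional assay on the whole organism for positive allosteric modulation, with Rattus norvegicus as the target (a higher number here means that more compound is needed for the effect, a lower number that less compound is needed), compound 2 gives 2.5 mg/kg, level with compound 1 at the digits shown, and the step of no change at the digits printed from compound 1 to compound 2 (within the scatter) stays within the scatter. Compound 3, `Cc1nn(C)c2c1C(c1cccc(N=[N+]=[N-])c1)=NCCN2`, has not yet been measured; it differs from compound 2 in one place: azido in place of amino on an aromatic carbon. Going by the values given here, only one measured step bears on this change, no change at the digits printed from compound 1 to compound 2 (within the scatter), which exchanged one group for another at the same aromatic carbon without moving the dose. Following that precedent, the expected step of no change at the digits printed from compound 2 to compound 3 (within the scatter) is none beyond the scatter. Compound 3 is therefore estimated at 2.5 mg/kg, with a range from 1.2 mg/kg to 5 mg/kg.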

Compound 3, minimum effective dose: 2.5 mg/kg
Estimate against measurement, compound 3: no gap at the digits printed, within the range that was stated.
By their numbers in this assay, from the lowest: compounds 1, 2 and 3 (each within the scatter of the next).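

In this assay, the step of no change at the digits printed from compound 2 to compound 3 (within the scatter) shows that this aromatic carbon, meta to a large group, accepts azido, with 3 heavy atoms and 0 hydrogen-bond donors, in place of amino, with 1 heavy atom and 1 hydrogen-bond donor. The step of no change at the digits printed from compound 1 to compound 3 (within the scatter) gives the same reading against fluoro, so all three groups now stand level at this position, and across amino and azido the dose does not follow the count of heavy atoms or hydrogen-bond donors. No measurement here explains why the dose stays level.

As far as these compounds go, it remains open whether a carboxylic acid, a butyl chain or a phenyl ring on this carbon would also leave the dose unmoved. From the compounds shown here alone, it is also open whether azido, amino and fluoro would sit level on another carbon of the ring.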